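Nitro for Phenyl on a Shared Core: Expected Cytotoxicity

The source may report more compounds than this note shows. Statements on the series, on what has been measured and on what is new or still open speak of the compounds shown alone.

Compound 1 `COc1cc(-c2nnc3n2NC(c2cccs2)C(C(=O)c2ccccc2)S3)cc(OC)c1OC`, in a functional assay on HepG2 cells (Homo sapiens) for cytotoxicity, read by MTT assay, with a stated time of 48 h (a higher number here means a weaker inhibitor, a lower number a stronger inhibitor), a limit of > 100000 nM.
Compound 2 `COc1cc(-c2nnc3n2NC(c2ccco2)C(C(=O)c2ccc(-c4ccccc4)cc2)S3)cc(OC)c1OC`, in this assay a limit of > 100000 nM.
Compound 3 `COc1cc(C(=O)C2Sc3nnc(-c4cc(OC)c(OC)c(OC)c4)n3NC2c2cccs2)cc(OC)c1OC`, in this assay a limit of > 100000 nM.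

Compound 2 stands at the limit of this assay, where every value shown sits (the limit of > 100000 nM in this assay, at which 3 of the 3 values shown sit). Going by the values given here, the single step measured, a step that the two limits leave unreadable from compound 1 to compound 3, is left unreadable by the two limits. Compound 4 `COc1cc(-c2nnc3n2NC(c2ccco2)C(C(=O)c2ccc([N+](=O)[O-])cc2)S3)cc(OC)c1OC` differs from compound 2 by nitro in place of phenyl on an aromatic carbon. No measured step touches this change, so nothing shown argues for a move away from the limit. Compound 4 is therefore expected to give about 100000 nM, with a range from 30000 nM to 300000 nM. The step of a number no higher from compound 2 to compound 4 (the limit leaves the size open) is expected to be no more than the scatter.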

Compound 4, half-maximal inhibitory concentration: 87800 nM
The estimate for compound 4 lay 1.1-fold (0.06 log units) above the measured number; measured number inside the range.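

In this assay, compound 4 is the only compound shown with a number rather than a limit: the limit of > 100000 nM in this assay, at which 3 of the 4 values shown sit. Nitro in place of phenyl gives an at least 1.1-fold lower number from compound 2 to compound 4 (0.05 log units; that floor lies within the scatter), so this position can carry a 4-nitrophenyl group and yield a readable value. From the compounds shown here alone, the value of compound 2 is only a limit, however, so the true size of this step remains unknown.

Going by these compounds, what an amine or a carboxylic acid at this same position would give remains open, as does whether nitro would give a readable value on compound 1.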